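The compounds below may be only part of what the source reports. "The series", "measured", "known", "first", "only" and "open" are said of these compounds alone.

Of the compounds shown here, three sharing one core have been measured in an assay for binding affinity to dual specificity mitogen-activated protein kinase kinase 4 (Homo sapiens), read by KINOMEscan, tested at 100 nM; on this read-out lower numbers stand for a stronger effect and higher numbers for a weaker effect at the one concentration tested. Compound 1 `CCCS(=O)(=O)Nc1ccc(F)c(C(=O)c2n[nH]c3ncc(-c4cccc(N)c4)cc23)c1F` gives 1.6%. Compound 2 `CCCS(=O)(=O)Nc1ccc(F)c(C(=O)c2n[nH]c3ncc(-c4ccc(N(C)C)cc4)cc23)c1F` gives 2.5%, and the step of a number 0.9 percentage points higher from compound 1 to compound 2 (within the scatter). Compound 3 `CCCS(=O)(=O)Nc1ccc(F)c(C(=O)c2n[nH]c3ncc(-c4ccc(C(C)C)cc4)cc23)c1F` gives 17%; this is the highest of the three numbers, so compound 3 binds least strongly of the set, since the steps of a number 15.4 percentage points higher from compound 1 to compound 3 (beyond the scatter) and a number 14.5 percentage points higher from compound 2 to compound 3 (beyond the scatter) both lie beyond the scatter.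

Compound 4 `CCCS(=O)(=O)Nc1ccc(F)c(C(=O)c2n[nH]c3ncc(-c4ccc(OC)cc4Cl)cc23)c1F` has not yet been measured. It differs from compound 3 in one place: 2-chloro-4-methoxyphenyl in place of 4-isopropylphenyl on an aromatic carbon. The two measured steps that bear on this position, from compound 1 and from compound 2 to compound 3, both show that exchanging the 4-isopropylphenyl group moves the number by a modest amount, and both other groups tried at this place gave lower numbers than the 4-isopropylphenyl group. No group with a chlorine or a methoxy has been measured, so the direction rests only on this pattern. A modest step downward, of a size comparable to those two steps, is expected, as a number 9 percentage points lower from compound 3 to compound 4 (within the scatter).

Compound 4 is therefore estimated to give 8% in this assay, with a range from 2% to 25%.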

Compound 4, a percentage reported as activity, at one concentration (the size of the read-out at that concentration, not a potency): 5.3%
The estimate for compound 4 lay 2.7 percentage points above the measured number; the range from low to high includes it.
By their numbers in this assay, from the lowest: compounds 1, 2 and 4 (each within the scatter of the next); then compound 3.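

In this assay, 2-chloro-4-methoxyphenyl in place of 4-isopropylphenyl gives a number 11.7 percentage points lower from compound 3 to compound 4 (beyond the scatter) and shows that lowering the number at this place does not depend on the two amino-bearing phenyl groups seen earlier. Set against those groups, the new ring gives a number 2.8 percentage points higher from compound 2 to compound 4 (within the scatter) and a number 3.7 percentage points higher from compound 1 to compound 4 (within the scatter), so a phenyl ring with a chlorine and a methoxy, and no nitrogen, falls in with them, and among these four compounds only compound 3 stands apart. No measurement here explains why these groups differ in this way.

Compound 4 brings in the chlorine and the methoxy together, so the compounds shown cannot tell how much of the step from compound 3 belongs to either one, and a phenyl ring carrying only the methoxy or only the chlorine would separate the two. Going by these compounds, it also remains open how this place would respond to a carboxylic acid or a morpholine ring on the phenyl, or to a plain phenyl ring with no added group.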